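Nitrooxy chain shortening on the phenol ester series

This account rests on a few compounds, and the source may have more. Where it says the series, first, only, none or still open, it means among the compounds named here.

Measured in a functional assay on LOX IMVI cells (Homo sapiens) for cytotoxicity, read by resazurin assay, with a stated time of 72 h; a lower number here means a stronger inhibitor, a higher number a weaker inhibitor:
- Compound 1 `COc1cc(/C=C/C(=O)OCCCO[N+](=O)[O-])ccc1OCCCO[N+](=O)[O-]` gives > 50000 nM
- Compound 2 `COc1cc(/C=C/C(=O)OCCCCCO[N+](=O)[O-])ccc1O` gives > 50000 nM

Compound 2 stands at > 50000 nM, which is a limit of the assay and not a number. The entry for compound 1 is also a limit. Going by the values given here, the record so far is therefore (the limit of > 50000 nM in this assay, at which 2 of the 2 values shown sit), and no measured step is available.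

The move to compound 3 `COc1cc(/C=C/C(=O)OCCCO[N+](=O)[O-])ccc1O` is nitrooxy in place of 2-(nitrooxy)ethyl on a saturated chain carbon, three bonds along the chain from an oxygen next to a carbonyl group. It places nitrooxy in place of 2-(nitrooxy)ethyl on a saturated chain carbon, three bonds along the chain from an oxygen next to a carbonyl group.

In this assay no step beyond the scatter is expected, because of the limit of > 50000 nM in this assay, at which 2 of the 2 values shown sit. The expected step is a number no higher from compound 2 to compound 3 (the limit leaves the size open). For compound 3 the estimate is 50000 nM, with an expected range from 20000 nM to 80000 nM.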

Compound 3, half-maximal inhibitory concentration: 29500 nM
Estimate against measurement, compound 3: 1.7-fold (0.23 log units) above, within the range that was stated.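

In this assay, going by these compounds alone, compound 3 gives 29500 nM, the first reading that is a number and not a limit. On the saturated chain carbon, nitrooxy in place of 2-(nitrooxy)ethyl goes with an at least 1.6-fold lower number from compound 2 to compound 3 (0.22 log units; that floor lies within the scatter), and on the oxygen on an aromatic ring, hydrogen in place of 3-(nitrooxy)propyl goes with an at least 1.6-fold lower number from compound 1 to compound 3 (0.22 log units; that floor lies within the scatter). Each step is only a floor, and neither can yet be said to exceed the scatter, which leaves the true size of both changes unknown: the limit of > 50000 nM in this assay, at which 2 of the 3 values shown sit.

The compounds shown do not tell whether the reading at compound 3 depends on nitrooxy, as none carries an amine or a carboxylic acid in its place. On these data alone, how a chain of another length would read on the shared core, with the aromatic oxygen kept as in compound 3, also stays open.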